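Amide series: removing one methyl from the 2-methylphenyl group

A few compounds are considered here, and "the series" means these few. Any claim that something is new, unique, unknown or untested is made for them only; others in the source may bear on it.

Compound 1 (`CCCC(=O)Nc1ncc(-c2ccc(OC)cc2)n1C`) gives > 100000 nM as a limit
Compound 2 (`COc1ccc(-c2cnc(NC(=O)c3ccccc3C)n2C)cc1`) gives > 100000 nM as a limit

In a toxicity assay on THP-1 cells (Homo sapiens) for inhibition (a higher number here means that more compound is tolerated, a lower number that less compound is tolerated), compound 2 stands at > 100000 nM as a limit of the assay, not as a number. Compound 3 (`COc1ccc(-c2cnc(NC(=O)c3ccccc3)n2C)cc1`) differs from compound 2 by hydrogen in place of methyl on an aromatic carbon and so has hydrogen in place of methyl on an aromatic carbon, turning 2-methylphenyl to phenyl. Going by the values given here, the only measured step that bears on this change is a step that the two limits leave unreadable from compound 1 to compound 2 and it gives no size to work from. All the data in this assay amount to the limit of > 100000 nM in this assay, at which 2 of the 2 values shown sit, and nothing more. No step beyond the scatter is therefore expected, and a further limit is the likely result. The expected change, a number no higher from compound 2 to compound 3 (the limit leaves the size open) in this assay, is an estimate resting on very little. For compound 3 the estimated value is 100000 nM with an expected range from 50000 nM to 200000 nM in this assay.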

Compound 3, half-maximal cytotoxic concentration: > 100000 nM
Compound 3: no number, only a limit; the forecaster's own chance of this, stated with the estimate: 85%; the middle value sits exactly at the limit.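

No step can be read among compound 1, compound 2 and compound 3, since each gives only a limit of the assay and not a number: the limit of > 100000 nM in this assay, at which 3 of the 3 values shown sit.

Still open, as far as these compounds go, is whether any group on the carbonyl carbon of this amide series gives a readable value in this assay.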